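This account rests on a few compounds, and the source may have more. Where it says the series, first, only, none or still open, it means among the compounds named here.

Within the data shown here, in a functional assay on HepG2 cells (Homo sapiens) for cytotoxicity, read by MTT assay, with a stated time of 48 h (a higher number here means a weaker inhibitor, a lower number a stronger inhibitor), compound 2 `CCCCCCCCCCCCCCNC(=O)[C@@H](NC(=O)c1cccs1)[C@@H](C)O` gives 88400 nM, the second highest of the three numbers so far. Compound 1 `CCCCCCCCNC(=O)[C@@H](NC(=O)c1cccs1)[C@@H](C)O` gives 149000 nM, and lengthening its chain reads a 1.7-fold lower number from compound 1 to compound 2 (0.23 log units; within the scatter). Compound 3 `CCCCCCCCCCCCCCNC(=O)[C@@H](NC(=O)c1nccc2ccccc12)[C@@H](C)O` gives 28600 nM, after a swap of the ring on the carbonyl carbon that reads a 3.1-fold lower number from compound 2 to compound 3 (0.49 log units; beyond the scatter). Compound 4 `CCCCCCCCCCCCCCNC(=O)[C@@H](NS(=O)(=O)c1cccs1)[C@@H](C)O` differs from compound 2 by (thiophen-2-yl)sulfonyl in place of (thiophen-2-yl)carbonyl on an amine nitrogen. Neither measured step touches this carbonyl-to-sulfonyl exchange: one alters the chain, the other the ring on the carbonyl carbon, so there is no direct guide. The step expected is a 1.0-fold lower number from compound 2 to compound 4 (0.00 log units; within the scatter), nothing beyond the scatter. Compound 4 is therefore estimated at 88000 nM, within a range from 30000 nM to 260000 nM.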

Compound 4, half-maximal inhibitory concentration: 21600 nM
For compound 4 the middle estimate is 4.1-fold (0.61 log units) above the measured one; measured number outside the range, below it.
By their numbers in this assay, from the lowest: compounds 4 and 3 (each within the scatter of the next); then compounds 2 and 1 (each within the scatter of the next).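

Exchanging (thiophen-2-yl)carbonyl for (thiophen-2-yl)sulfonyl on the amine nitrogen, with the thiophene ring and the long chain unchanged, gives a 4.1-fold lower number from compound 2 to compound 4 (0.61 log units; beyond the scatter). Among these compounds, the earlier steps altered only the chain or the ring, so this is the first sign that the group joining the ring to that nitrogen can also shift the number beyond the scatter. No measurement shown here accounts for this shift.

As far as these compounds go, whether the sulfonyl exchange gives a similar step with the isoquinolin-1-yl ring or the shorter chain of compound 1 remains open. So does the outcome with a plain methylene in place of the carbonyl.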